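Shifting the methoxy group on the anilide ring

The source may report more compounds than this note shows. Statements on the series, on what has been measured and on what is new or still open speak of the compounds shown alone.

Among the compounds with values here, compound 2 `COc1ccc(NC(=O)/C=C/c2coc3cc(OC)ccc3c2=O)cc1` is the only compound with a number in a functional assay on A549 cells (Homo sapiens) for inhibition, read by MTT assay, with a stated time of 48 h; a higher number here means a weaker inhibitor, a lower number a stronger inhibitor: in this assay compound 2 gives 23000 nM. Compound 1 `COc1ccc2c(=O)c(/C=C/C(=O)NCc3ccc(C)cc3)coc2c1` is known in this assay only as a limit; compound 1 gives > 100000 nM, which is a limit of the assay and not a number (the limit of > 100000 nM in this assay, at which 1 of the 2 values shown sits). Within the data shown here, the single measured step, an at least 4.3-fold lower number from compound 1 to compound 2 (0.63 log units; beyond the scatter), exchanges the whole group on the amide-type nitrogen. Compound 3 `COc1cccc(NC(=O)/C=C/c2coc3cc(OC)ccc3c2=O)c1` keeps the same atoms and differs from compound 2 in 3-methoxyphenyl in place of 4-methoxyphenyl on an amide-type nitrogen. Among the measured compounds shown here, no measured step moves only the methoxy group around the phenyl ring, so the step from compound 1 to compound 2 gives no direct guide, and no step beyond the scatter is expected in this assay. Compound 3 is therefore estimated at 23000 nM, with a range from 8000 nM to 70000 nM. The expected step of no change at the digits printed from compound 2 to compound 3 (within the scatter) lies within the scatter.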

Compound 3, half-maximal inhibitory concentration: 12800 nM
Estimate against measurement, compound 3: 1.8-fold (0.25 log units) above; the measured number falls inside the stated range.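

Moving the methoxy group on the ring attached to the amide-type nitrogen is the first change of its placement alone, and in this assay it gives a 1.8-fold lower number from compound 2 to compound 3 (0.25 log units; within the scatter), so the 3-methoxyphenyl and 4-methoxyphenyl groups cannot be told apart here. The exchange of 4-methylbenzyl for a methoxyphenyl group now reads beyond the scatter with both placements, with an at least 7.8-fold lower number from compound 1 to compound 3 (0.89 log units; beyond the scatter) joining the step already seen for the 4-methoxyphenyl group. The true size of both steps stays unknown because compound 1 is known only as a limit: the limit of > 100000 nM in this assay, at which 1 of the 3 values shown sits.

The compounds shown leave open whether the change from benzyl to phenyl or the change from methyl to methoxy carries these steps, which a 4-methylphenyl group on the same nitrogen would help separate. As far as these compounds go, how a hydroxyl or an amine in place of the methoxy group would read also remains open.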